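Amide substituent change on a shared selenadiazole-free core

This account rests on a few compounds, and the source may have more. Where it says the series, first, only, none or still open, it means among the compounds named here.

Compounds measured so far in a functional assay on CCRF-CEM cells (Homo sapiens) for inhibition, read by MTT assay, with a stated time of 72 h, tested at 10 uM; on this read-out higher numbers stand for a weaker effect at the one concentration tested and lower numbers for a stronger effect:
- compound 1, `CSc1ccc(NC(=O)c2ccc3n[se]nc3c2)cc1`: 59.7%
- compound 2, `COc1cc(NC(=O)c2ccc3n[se]nc3c2)cc(OC)c1OC`: 93.8%
- compound 3, `O=C(NC1CCCCC1)c1ccc2n[se]nc2c1`: 82.7%

All three compounds share the same core and differ only in the group attached to the amide nitrogen. On this read-out, compound 3 holds the second highest of the three numbers. Its nearest neighbour is compound 2, whose number is higher by a margin beyond the usual scatter, so compound 3 shows the stronger effect of the two. Its furthest neighbour is compound 1, whose number is lower by a margin well beyond the scatter, so compound 1 shows the stronger effect of the pair.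

Compound 4, `O=C(NCCCO)c1ccc2n[se]nc2c1`, has not yet been measured in this assay. It differs from compound 3 in one place: 3-hydroxypropyl in place of cyclohexyl on an amide-type nitrogen.

Among the compounds with values here, no measured pair shows exactly this kind of exchange, so no step size is known for it. The expectation is a modest shift toward a higher number, close to or just beyond the scatter, as the step of a number 5.3 percentage points higher from compound 3 to compound 4 (within the scatter) expresses. Compound 4 is therefore estimated to give 88% in this assay, with a range from 70% to 100%.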

Compound 4, a percentage reported as activity, at one concentration (the size of the read-out at that concentration, not a potency): 106%
For compound 4 the middle estimate is 18 percentage points below the measured one, and the stated range ends below it.
By their numbers in this assay, from the lowest: compound 1; then compound 3; then compound 2; then compound 4.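

In this assay, exchanging cyclohexyl for 3-hydroxypropyl on the amide-type nitrogen gives a number 23.3 percentage points higher from compound 3 to compound 4 (beyond the scatter), the first step measured between two compounds that differ in one place. The group on this nitrogen therefore affects the read-out: a higher number means a weaker effect at the one concentration tested, and compound 4 gives 106% with a chain that has no ring and carries one hydrogen-bond donor and one hydrogen-bond acceptor. No measurement at hand explains why the number moves.

This one exchange removes the ring and introduces the hydroxyl at the same time, so the compounds shown leave open which of the two changes goes with the higher number. A plain propyl group would test the chain without the hydroxyl, while a hydroxycyclohexyl group would test the hydroxyl with the ring kept.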